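A few compounds are considered here, and "the series" means these few. Any claim that something is new, unique, unknown or untested is made for them only; others in the source may bear on it.

Working notes on the series. In a functional assay on UACC-62 cells (Homo sapiens) for inhibition, read by sulforhodamine B assay, with a stated time of 48 h (on this read-out lower numbers stand for stronger inhibition of growth and higher numbers for weaker inhibition of growth), compound 1 `O=C(Cc1csc2nc(-c3ccc(Br)cc3)cn12)N/N=C/c1ccccc1` gives 11500 nM. Under the same read-out, compound 2 `O=C(Cc1csc2nc(-c3ccc(Br)cc3)cn12)N/N=C/c1ccc(O)cc1` gives 9120 nM, and compound 3 `COc1cccc(OC)c1/C=N/NC(=O)Cc1csc2nc(-c3ccc(Br)cc3)cn12` gives 12000 nM. Compound 1 therefore lies within the scatter of both other compounds, and the three numbers show no meaningful order.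

The next compound, compound 4 `O=C(Cc1csc2nc(-c3ccc(Br)cc3)cn12)N/N=C/c1ccc(Cl)cc1Cl`, has not yet been measured. It differs from compound 1 at a single place: 2,4-dichlorophenyl in place of phenyl on a carbon with a double bond to nitrogen. In words, this is 2,4-dichlorophenyl in place of phenyl on a carbon with a double bond to nitrogen.

For the measured compounds named here, three measured steps bear on this change. Hydroxy in place of hydrogen on an aromatic carbon gives a 1.3-fold lower number from compound 1 to compound 2 (0.10 log units; within the scatter). 2,6-Dimethoxyphenyl in place of phenyl gives a 1.0-fold higher number from compound 1 to compound 3 (0.02 log units; within the scatter), and the swap between those two substituted rings gives a 1.3-fold higher number from compound 2 to compound 3 (0.12 log units; within the scatter). All three stay within the scatter. Going by the values given here, none of the measured compounds carries chlorine, so the data offer no direct precedent for this substituent, and the range is kept wide.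

No shift beyond the scatter is expected in this assay, and the expected step is a 1.3-fold lower number from compound 1 to compound 4 (0.11 log units; within the scatter). The estimated value for compound 4 is 9000 nM, with an expected range of 4000 nM to 18000 nM.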

Compound 4, concentration for 50% growth inhibition: 23400 nM
Compound 4: middle estimate off by 2.6-fold (0.41 log units), on the low side; the whole stated range lies below it.
By their numbers in this assay, from the lowest: compounds 2, 1, 3 and 4 (each within the scatter of the next, the first and the last beyond it).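

For the compounds shown here, at this place, on a carbon with a double bond to nitrogen, this assay now shows steps that leave the scatter: 2,4-dichlorophenyl in place of phenyl gives a 2.0-fold higher number from compound 1 to compound 4 (0.31 log units; beyond the scatter) and is modest in size, and 2,4-dichlorophenyl in place of 4-hydroxyphenyl gives a 2.6-fold higher number from compound 2 to compound 4 (0.41 log units; beyond the scatter) and is also modest, whereas every step among the earlier compounds stayed within the scatter. The ring at this place can therefore move the number towards weaker inhibition of growth, although the change is not separated from every earlier ring, since 2,4-dichlorophenyl in place of 2,6-dimethoxyphenyl gives a 2.0-fold higher number from compound 3 to compound 4 (0.29 log units; within the scatter) and stays within the scatter. No measurement in hand accounts for this shift, so its origin remains unassigned.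

Still open, on these data alone, is whether a single chlorine on the phenyl ring would give the same shift as the two chlorines of compound 4. Also open, as far as these compounds go, is whether an amine or a carboxylic acid on that ring would move the number the other way, towards stronger inhibition of growth.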